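The source may report more compounds than this note shows. Statements on the series, on what has been measured and on what is new or still open speak of the compounds shown alone.

Measured compounds:
compound 1 `CC1(C)c2[nH]nc(NC(=O)c3ccc(F)cc3)c2CN1Cc1cc(F)cc(F)c1` gives 350 nM in an assay on Sf21 cells for inhibition of high affinity nerve growth factor receptor (Homo sapiens), read by HTRF, with a stated time of 30 min, in the presence of a further agent that is not named here; a higher number here means a weaker inhibitor, a lower number a stronger inhibitor
compound 2 `CN(C)c1ccc(C(=O)Nc2n[nH]c3c2CN(Cc2cc(F)cc(F)c2)C3(C)C)cc1` gives 96 nM in this assay

For the measured compounds named here, compound 2 stands at the lowest of the two numbers; the single measured step, a 3.6-fold lower number from compound 1 to compound 2 (0.56 log units; beyond the scatter), separates it from its nearest neighbour. Compound 3 `CN(C)c1cccc(C(=O)Nc2n[nH]c3c2CN(Cc2cc(F)cc(F)c2)C3(C)C)c1` differs from compound 2 by 3-(dimethylamino)phenyl in place of 4-(dimethylamino)phenyl on a carbonyl carbon. Going by the values given here, that one step exchanged the group on the ring rather than moving it, so no measured pair bears directly on this rearrangement. The step from compound 2 to compound 3 is therefore expected to be small, within or near the scatter, a 1.7-fold higher number from compound 2 to compound 3 (0.22 log units; within the scatter). Compound 3 is estimated at 160 nM, with a range of 60 nM to 450 nM.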

Compound 3, half-maximal inhibitory concentration: 270 nM
The estimate for compound 3 lay 1.7-fold (0.23 log units) below the measured number, within the range that was stated.
By their numbers in this assay, from the lowest: compound 2; then compounds 3 and 1 (each within the scatter of the next).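

The position of the dimethylamino group on the phenyl ring matters in this assay, as 3-(dimethylamino)phenyl in place of 4-(dimethylamino)phenyl gives a 2.8-fold higher number from compound 2 to compound 3 (0.45 log units; beyond the scatter) and so gives up most of what compound 2 showed. Against 4-fluorophenyl, the same group gives a 1.3-fold lower number from compound 1 to compound 3 (0.11 log units; within the scatter) and does not stand apart from it. No measurement at hand explains this difference.

Still open, going by these compounds, is whether a cyclic amine such as morpholine or piperazine, in place of dimethylamino, would match or improve on compound 2.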